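Working notes: methylsulfanyl analogue of compound 2

The source may hold more compounds than are shown below. What is called first, only, known or untested is meant among the compounds shown, and "the series" means these compounds.

The series shares one core and varies the group on the six-membered aromatic ring of carbon only. Compound 1 `CC(=O)Nc1ccc(NC(=O)c2cn(Cc3c(F)cccc3F)c3ccc(=O)[nH]c3c2=O)cc1` carries acetamido there; in an in vitro assay on Sf21 cells for inhibition of high affinity 3',5'-cyclic-AMP phosphodiesterase 7A (Homo sapiens), read by scintillation proximity assay, with a stated time of 30 min (a lower number here means a stronger inhibitor, a higher number a weaker inhibitor), compound 1 gives 24 nM. Compound 2 `O=C(Nc1ccccc1)c1cn(Cc2c(F)cccc2F)c2ccc(=O)[nH]c2c1=O` carries hydrogen at that carbon, and in this assay compound 2 gives 94 nM, the second highest of the three numbers. Compound 3 `O=C(O)Cc1ccc(NC(=O)c2cn(Cc3c(F)cccc3F)c3ccc(=O)[nH]c3c2=O)cc1` carries carboxymethyl, and in this assay compound 3 gives 176 nM. The step of a 3.9-fold higher number from compound 1 to compound 2 (0.59 log units; beyond the scatter) is the only move beyond the scatter; the step of a 1.9-fold higher number from compound 2 to compound 3 (0.27 log units; within the scatter) stays within it. Compound 4 `CSc1ccc(NC(=O)c2cn(Cc3c(F)cccc3F)c3ccc(=O)[nH]c3c2=O)cc1` differs from compound 2 by methylsulfanyl in place of hydrogen on an aromatic carbon. Of the two measured replacements of hydrogen at this carbon, acetamido lowered the number and carboxymethyl left it within the scatter, so for compound 4 a modest lowering is expected, with a result within the scatter of compound 2 also plausible. Compound 4 is estimated at 55 nM in this assay, with a range of 22 nM to 140 nM, an expected step of a 1.7-fold lower number from compound 2 to compound 4 (0.23 log units; within the scatter).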

Compound 4, half-maximal inhibitory concentration: 86 nM
The estimate for compound 4 lay 1.6-fold (0.19 log units) below the measured number; the range from low to high includes it.
By their numbers in this assay, from the lowest: compound 1; then compounds 4, 2 and 3 (each within the scatter of the next, the first and the last beyond it).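

In this assay, methylsulfanyl on this aromatic carbon, para to a large group, stays level with hydrogen: a 1.1-fold lower number from compound 2 to compound 4 (0.04 log units; within the scatter). Acetamido is therefore the only one of the three replacements shown that stands apart from hydrogen, and it also stands apart from methylsulfanyl, with a 3.6-fold higher number from compound 1 to compound 4 (0.55 log units; beyond the scatter). Methylsulfanyl and carboxymethyl, which are each within the scatter of hydrogen, are separated from each other, though only narrowly, with a 2.0-fold lower number from compound 3 to compound 4 (0.31 log units; beyond the scatter). Nothing available here bears on the reason for these numbers.

The compounds shown leave open whether the lower number of compound 1 belongs to the whole acetamido group, which an amine or a methoxy group on this carbon would help to test. Also open, as far as these compounds go, is whether a longer chain on the sulfur would stay level with methylsulfanyl.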